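The source may hold more compounds than are shown below. What is called first, only, known or untested is meant among the compounds shown, and "the series" means these compounds.

Measured in a functional assay on ACHN cells (Homo sapiens) for cytotoxicity, read by sulforhodamine B assay, with a stated time of 72 h; a higher number here means a weaker inhibitor of growth, a lower number a stronger inhibitor of growth:
Compound 1 `CC(=O)N1c2ccccc2CCC1C(=O)Nc1cc(C(F)(F)F)cc(C(F)(F)F)c1`: > 70000 nM (a limit)
Compound 2 `CCCC(=O)N1c2ccccc2CCC1C(=O)Nc1ccccc1C(F)(F)F`: > 70000 nM (a limit)

In this assay, compound 2 gives only a limit, > 70000 nM, and no number. Compound 2 sits at the limit of > 70000 nM in this assay, at which 2 of the 2 values shown sit. Compound 3 `O=C(Nc1ccccc1C(F)(F)F)C1CCc2ccccc2N1` has hydrogen in place of propylcarbonyl on a nitrogen on an aromatic ring in a ring. Among the compounds with values here, no measured step shows the effect of this change, so only a modest shift toward stronger growth inhibition is expected, and compound 3 may stay at the limit. For compound 3 the estimated value is 50000 nM, with an expected range of 15000 nM to 90000 nM. This estimate means an expected at least 1.4-fold lower number from compound 2 to compound 3 (0.14 log units; that floor lies within the scatter).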

Compound 3, concentration for 50% growth inhibition: 57600 nM
Compound 3: the middle estimate sits 1.2-fold (0.06 log units) below what was measured; measured number inside the range.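

Compound 3 is the only compound shown that gives a number rather than a limit in this assay, at 57600 nM. Hydrogen in place of propylcarbonyl on this nitrogen gives an at least 1.2-fold lower number from compound 2 to compound 3 (0.08 log units; that floor lies within the scatter), so the step does not establish that growth inhibition changed. Only a floor can be stated, since one end of the step is a limit: the limit of > 70000 nM in this assay, at which 2 of the 3 values shown sit.

The compounds shown leave open whether a methyl group, an amine or a carboxylic acid-bearing chain on this nitrogen would give a lower number than compound 3. They also do not show whether the trifluoromethyl group contributes to the value of compound 3.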